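This account rests on a few compounds, and the source may have more. Where it says the series, first, only, none or still open, it means among the compounds named here.

Measured compounds:
- compound 1, `COc1ccc(-c2snnc2-c2cc(OC)c(OC)c(OC)c2)cc1O`: 3 nM
- compound 2, `COc1ccc(-c2snnc2-c2cc(OC)c(OC)c(OC)c2)cc1[N+](=O)[O-]`: 30.2 nM
- compound 3, `COc1cc(-c2nnsc2-c2ccc(Cl)cc2)cc(OC)c1OC`: 18.5 nM

In a functional assay on HCT-116 cells (Homo sapiens) for antiproliferative activity (a higher number here means a weaker inhibitor, a lower number a stronger inhibitor), compound 1 gives the lowest of the three numbers. Its nearest neighbour is compound 3, which gives 18.5 nM in this assay, a gap beyond the scatter; the furthest is compound 2, which gives 30.2 nM. The one step that has been measured between two of these compounds is a 10-fold higher number from compound 1 to compound 2 (1.00 log units; beyond the scatter).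

Compound 4, `COc1ccc(-c2snnc2-c2cc(OC)c(OC)c(OC)c2)cc1`, is compound 1 with one change: hydrogen in place of hydroxy on an aromatic carbon, on an aromatic carbon of a six-membered aromatic ring of carbon only, ortho to a methoxy group and meta to a large group. Among the compounds with values here, no measured step replaces the hydroxy by hydrogen, so the nitro step stands as the only guide, and it only shows that altering this position in compound 1 can cost potency. A smaller loss than that step is expected here, though one still beyond the scatter. The estimated step in this assay is a 5.0-fold higher number from compound 1 to compound 4 (0.70 log units; beyond the scatter). Compound 4 is therefore expected to give about 15 nM in this assay, likely between 4 nM and 60 nM.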

Compound 4, half-maximal inhibitory concentration: 25 nM
For compound 4 the middle estimate is 1.7-fold (0.22 log units) below the measured one, within the range that was stated.
By their numbers in this assay, from the lowest: compound 1; then compounds 3, 4 and 2 (each within the scatter of the next).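

In this assay, the loss at this position does not depend on a nitro group: simply removing the hydroxy gives an 8.3-fold higher number from compound 1 to compound 4 (0.92 log units; beyond the scatter). Hydrogen and nitro on this aromatic carbon cannot be told apart, with a 1.2-fold lower number from compound 2 to compound 4 (0.08 log units; within the scatter), so of the three groups tried here, only hydroxy gives a distinctly lower number. At the other place where the compounds vary, a 1.4-fold higher number from compound 3 to compound 4 (0.13 log units; within the scatter) likewise leaves methoxy and chloro on that aromatic carbon unseparated.

The compounds shown leave open whether an amine, a fluorine or a hydroxymethyl group on this carbon would keep the number of compound 1 or fall with hydrogen and nitro. Nothing available here accounts for what sets hydroxy apart at this position.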